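Tosylation of the phenol in a triazole-bearing diterpenoid core

A few compounds are considered here, and "the series" means these few. Any claim that something is new, unique, unknown or untested is made for them only; others in the source may bear on it.

Measured so far:
- compound 1, `C=C1C(=O)[C@]23C[C@@]1(O)CC[C@H]2c1ccc(OS(=O)(=O)c2ccc(C)cc2)c(C)c1[C@@H]3Cn1cc(-c2ccc(Br)cc2)nn1`, 4320 nM in a functional assay on SMMC-7721 cells (Homo sapiens) for cytotoxicity, read by MTT assay, with a stated time of 4 days; on this read-out higher numbers stand for weaker inhibition and lower numbers for stronger inhibition
- compound 2, `C=C1C(=O)[C@]23C[C@@]1(O)CC[C@H]2c1ccc(O)c(C)c1[C@@H]3Cn1cc(-c2ccccc2)nn1`, 1320 nM in this assay
- compound 3, `C=C1C(=O)[C@]23C[C@@]1(O)CC[C@H]2c1ccc(O)c(C)c1[C@@H]3Cn1cc(-c2ccc(C)cc2)nn1`, 920 nM in this assay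

Among these three, compound 3 has the lowest number in this assay. Its nearest neighbour is compound 2, and the step of a 1.4-fold lower number from compound 2 to compound 3 (0.16 log units; within the scatter) lies within the scatter, so the two cannot be ranked against each other. Compound 1 stands further away, and that gap is beyond the scatter.

Compound 4, `C=C1C(=O)[C@]23C[C@@]1(O)CC[C@H]2c1ccc(OS(=O)(=O)c2ccc(C)cc2)c(C)c1[C@@H]3Cn1cc(-c2ccc(C)cc2)nn1`, is the next compound to be measured. It differs from compound 3 in one place: (4-methylphenyl)sulfonyl in place of hydrogen on an oxygen on an aromatic ring. Among the compounds with values here, no measured pair isolates exactly this change. Within the data shown here, the only bearing comes from compound 1, which carries the same ((4-methylphenyl)sulfonyl)oxy group but also a bromo instead of a methyl on the triazole-linked phenyl, and whose value sits well above that of compound 3. If most of that gap belongs to the sulfonyl group, compound 4 is expected to move toward the number of compound 1.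

The estimate for compound 4 in this assay is therefore 3000 nM, with a range from 1200 nM to 8000 nM. That estimate means a step of a 3.3-fold higher number from compound 3 to compound 4 (0.51 log units; beyond the scatter), expected to lie beyond the scatter toward weaker inhibition.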

Compound 4, half-maximal inhibitory concentration: 4410 nM
Compound 4: middle estimate off by 1.5-fold (0.17 log units), on the low side; the measured number falls inside the stated range.
By their numbers in this assay, from the lowest: compounds 3 and 2 (each within the scatter of the next); then compounds 1 and 4 (each within the scatter of the next).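

In this assay, the change from hydroxy to ((4-methylphenyl)sulfonyl)oxy on the aromatic ring can now be read on its own, as a single difference between two compounds: a 4.8-fold higher number from compound 3 to compound 4 (0.68 log units; beyond the scatter) is a step toward weaker inhibition, beyond the scatter, so the free hydroxy compound and its sulfonylated partner can be ranked. With the sulfonyl group in place, methyl in place of bromo on the aromatic carbon gives a 1.0-fold higher number from compound 1 to compound 4 (0.01 log units; within the scatter), which lies within the scatter, so this pair cannot be ranked and the swap shows no readable effect here. No measurement shown gives a reason for the step toward weaker inhibition at this oxygen. 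

The compounds shown leave open whether any group on this oxygen gives the same step, or only this one; a methyl ether, an acetyl ester or a methanesulfonyl group would help separate the effect of covering the hydroxy from that of the added aromatic ring. Also open, going by these compounds, is whether a group such as an amine or a carboxylic acid on the triazole-linked phenyl would change the picture.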